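The source may hold more compounds than are shown below. What is called first, only, known or untested is meant among the compounds shown, and "the series" means these compounds.

Compound 3 `Cc1ccc(NC(=O)Nc2ccc(Oc3cc(N4CCNC[C@@H]4C)ncn3)cc2)cc1C(F)(F)F` gives 8120 nM in a functional assay on BaF3 cells (Mus musculus) for inhibition, read by CCK-8 assay, with a stated time of 72 h (on this read-out lower numbers stand for stronger inhibition of growth and higher numbers for weaker inhibition of growth), the higher of the two numbers recorded there; compound 2 `Cc1ccc(NC(=O)Nc2ccc(Oc3cc(/N=C/N(C)C)ncn3)cc2)cc1C(F)(F)F` gives 6610 nM, and the pair sit within the scatter of each other, so neither can be ranked above the other. Compound 1 `CNc1cc(Oc2ccc(NC(=O)Nc3ccc(C)c(C(F)(F)F)c3)cc2)ncn1` reaches only the limit of > 10000 nM, a limit rather than a number; the limit of > 10000 nM in this assay, at which 1 of the 3 values shown sits, marks where it sits.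

Compound 4 `COCCNc1cc(Oc2ccc(NC(=O)Nc3ccc(C)c(C(F)(F)F)c3)cc2)ncn1` differs from compound 3 in one place: (2-methoxyethyl)amino in place of 2-methylpiperazin-1-yl on an aromatic carbon. The measured steps that touch this position are small. Going an at least 1.2-fold lower number from compound 1 to compound 3 (0.09 log units; that floor lies within the scatter) and an at least 1.5-fold lower number from compound 1 to compound 2 (0.17 log units; that floor lies within the scatter) gave changes whose floors lie within the scatter, and a 1.2-fold higher number from compound 2 to compound 3 (0.09 log units; within the scatter) lies within it too. Nothing among these steps separates one amino-type substituent at this aromatic carbon from another beyond the scatter.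

Compound 4 is therefore expected to stay close to compound 3, with a 1.1-fold lower number from compound 3 to compound 4 (0.03 log units; within the scatter) estimated as no movement beyond the scatter, and an estimated value of 7500 nM, within a range from 3000 nM to 16000 nM.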

Compound 4, concentration for 50% growth inhibition: 7950 nM
The estimate for compound 4 lay 1.1-fold (0.03 log units) below the measured number; measured number inside the range.
By their numbers in this assay, from the lowest: compounds 2, 4 and 3 (each within the scatter of the next). At a limit, above all of these: compound 1.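

Replacing 2-methylpiperazin-1-yl, with its six-membered ring and defined stereocentre, by the ringless (2-methoxyethyl)amino gives a 1.0-fold lower number from compound 3 to compound 4 (0.01 log units; within the scatter) in this assay, so at this aromatic carbon, among the compounds shown, neither the ring nor the stereocentre is needed to hold the value. Against the other ringless group the result is a 1.2-fold higher number from compound 2 to compound 4 (0.08 log units; within the scatter), so an oxygen-bearing chain in place of that all-nitrogen group shifts nothing beyond the scatter. The remaining comparison, an at least 1.2-fold lower number from compound 1 to compound 4 (0.09 log units; that floor lies within the scatter), gives only a floor, since compound 1 stands at a limit and not a number: the limit of > 10000 nM in this assay, at which 1 of the 4 values shown sits.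

The compounds shown leave open whether any group at this carbon can move the number beyond the scatter. A carboxylic acid, a morpholine ring or a longer chain ending in an amine would each test this.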